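Ethynyl in place of thiophen-2-yl on two related cores

The compounds below may be only part of what the source reports. "The series", "measured", "known", "first", "only" and "open" are said of these compounds alone.

Of the compounds shown here, three have been tested in a functional assay on CCRF-CEM cells (Homo sapiens), read by MTT assay, with a stated time of 72 h; on this read-out lower numbers stand for stronger inhibition and higher numbers for weaker inhibition. Compound 1 `C#Cc1cn([C@@H]2O[C@H](CO)[C@@H](O)[C@H]2O)c2ncnc(C)c12` gives 5600 nM. Compound 3 `Cc1ncnc2c1c(-c1cccs1)cn2[C@@H]1O[C@H](CO)[C@@H](O)[C@H]1O` is reported only as a limit of the assay, > 20000 nM. Compound 2 `COc1nc(N)nc2c1c(-c1cccs1)cn2[C@@H]1O[C@H](CO)[C@@H](O)[C@H]1O` is likewise reported only as a limit, > 20000 nM. How the cores of compound 2 and compound 3 differ is not broken down here.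

Within the data shown here, the one change measured so far, (ethynyl in place of thiophen-2-yl on an aromatic carbon), produced an at least 3.5-fold lower number from compound 3 to compound 1 (0.55 log units; beyond the scatter). Only the smallest possible size of that step is known because the limit of > 20000 nM in this assay, at which 2 of the 3 values shown sit, hides anything weaker.

Compound 4 `C#Cc1cn([C@@H]2O[C@H](CO)[C@@H](O)[C@H]2O)c2nc(N)nc(OC)c12` carries the same change on the core of compound 2, (ethynyl in place of thiophen-2-yl on an aromatic carbon), and the surroundings of the place match word for word. A step of an at least 2.5-fold lower number from compound 2 to compound 4 (0.39 log units; beyond the scatter) is expected, resting on an at least 3.5-fold lower number from compound 3 to compound 1 (0.55 log units; beyond the scatter). Compound 4 is therefore estimated at 8000 nM, though it may still be reported only as a limit.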

Compound 4, half-maximal inhibitory concentration: > 100000 nM
Compound 4 was reported as a limit; the forecaster's own chance of this, stated with the estimate: 35%; at least 12-fold (1.09 log units) between middle value and limit.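

Compound 2 and compound 4 are both reported only as limits, so the step between them cannot be read. Left open is whether ethynyl in place of thiophen-2-yl changes the read-out at all on the core of compound 2.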